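A few compounds are considered here, and "the series" means these few. Any claim that something is new, unique, unknown or untested is made for them only; others in the source may bear on it.

Three compounds built on a shared core were examined in a functional assay on HeLa cells (Homo sapiens) for cytotoxicity, read by MTT assay, with a stated time of 120 h; a lower number here means a stronger inhibitor, a higher number a weaker inhibitor. Compound 1 `COc1ccc2oc(=O)sc2c1C(=O)/C=C/c1ccccc1` gives 8400 nM in this assay. Compound 3 `COc1ccc(/C=C/C(=O)c2c(OC)ccc3oc(=O)sc23)cc1OC` gives 14100 nM in this assay; these two values lie within the usual scatter of each other, so no order between compound 1 and compound 3 can be read from them. Compound 2 `COc1ccc2oc(=O)sc2c1C(=O)/C=C/c1ccc([N+](=O)[O-])cc1` carries a nitro group, and in this assay compound 2 gives "not determined" (no result reported), so it has no place on the numbers that exist so far. Compound 4 `COc1ccc2oc(=O)sc2c1C(=O)/C=C/c1ccc(N(C)C)cc1` differs from compound 2 in a single place: dimethylamino in place of nitro on an aromatic carbon. Among the compounds with values here, no step between two measured compounds follows this exchange, and the two measured values, being within scatter of each other, give neither a size nor a direction for it. The expectation can therefore only be that compound 4 falls in the same region as the measured compounds, with no change beyond the scatter assumed in either direction. Because compound 1 gives 8400 nM and compound 3 gives 14100 nM, the estimate for compound 4 in this assay is 10000 nM, with a range from 3000 nM to 35000 nM.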

Compound 4, half-maximal inhibitory concentration: > 100000 nM
Compound 4 was reported as a limit; the forecaster's own chance of this, stated with the estimate: 20%; middle value at least 10-fold (1.00 log units) from the limit.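

In this assay, one group on an aromatic carbon of the six-membered aromatic ring of carbon only, para to a large group, turns out to be able to move the result a long way: dimethylamino in place of hydrogen gives an at least 11-fold higher number from compound 1 to compound 4 (1.07 log units; beyond the scatter). Compound 4 gives > 100000 nM, which is a limit of the assay and not a number. The true size of this step therefore stays unknown, but unlike the earlier compounds, this pair shows that the change is large and that it runs towards a weaker inhibitor, with the reading for this compound resting on a limit only: the limit of > 100000 nM in this assay, at which 1 of the 4 values shown sits.

Compound 2 has no reported result, so nitro and dimethylamino cannot be set against each other at this position, and any step involving compound 2 cannot be read. As far as these compounds go, it remains open whether a smaller amine such as a plain amino group, a fluorine or a carboxylic acid on the same aromatic carbon would behave like dimethylamino or stay close to the hydrogen of compound 1.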